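Working notes: from compound 3 to compound 4

The compounds below may be only part of what the source reports. "The series", "measured", "known", "first", "only" and "open" are said of these compounds alone.

Values in a functional assay on Ehrlich cells (Mus musculus) for antiproliferative activity, read by trypan blue exclusion, with a stated time of 2 h (on this read-out lower numbers stand for stronger inhibition and higher numbers for weaker inhibition), are as follows.
compound 1 `COc1ccc(C2C(C#N)=C(N)N(c3ccc(S(N)(=O)=O)cc3)C3=C2C(=O)CCC3)cc1` gives 25 ug/mL
compound 2 `N#CC1=C(N)N(c2ccc(S(N)(=O)=O)cc2)C2=C(C(=O)CCC2)C1c1ccc([N+](=O)[O-])cc1` gives 2.5 ug/mL
compound 3 `N#CC1=C(N)N(c2ccc(S(N)(=O)=O)cc2)C2=C(C(=O)CCC2)C1c1c(O)ccc2ccccc12` gives > 100 ug/mL (a limit of the assay)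

Compound 3 has no number and stands only at a limit (the limit of > 100 ug/mL in this assay, at which 1 of the 3 values shown sits). Compound 4 `Cc1ccoc1C1C(C#N)=C(N)N(c2ccc(S(N)(=O)=O)cc2)C2=C1C(=O)CCC2` is unmeasured and has 3-methylfuran-2-yl in place of 2-hydroxynaphthalen-1-yl on a saturated ring carbon. Two measured steps change the group at this carbon: an at least modest one (an at least 4.0-fold higher number from compound 1 to compound 3 (0.60 log units; beyond the scatter)) and a large one (an at least 40-fold higher number from compound 2 to compound 3 (1.60 log units; beyond the scatter)). A modest step (a 10-fold lower number from compound 1 to compound 2 (1.00 log units; beyond the scatter)) shows that the number also moves with the substituent on the aromatic ring. For the measured compounds named here, no measured compound carries 3-methylfuran-2-yl. Compound 4 lacks the 2-hydroxynaphthalen-1-yl group, as do compound 1 and compound 2, so a step of at least modest size towards a lower number is expected in this assay from the two steps above. The expected change is an at least 5.0-fold lower number from compound 3 to compound 4 (0.69 log units; beyond the scatter) (an estimate). For compound 4 the estimated value is 20 ug/mL within a range from 4 ug/mL to 80 ug/mL (an expectation).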

Compound 4, half-maximal inhibitory concentration: > 100 ug/mL
Compound 4: a limit, no number; the forecaster's own chance of this, stated with the estimate: 20%; at least 5.0-fold (0.69 log units) between middle value and limit.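

In this assay, a second group at the saturated ring carbon now falls well short of the two substituted phenyl groups: an at least 40-fold higher number from compound 2 to compound 4 (1.60 log units; beyond the scatter), and an at least 4.0-fold higher number from compound 1 to compound 4 (0.60 log units; beyond the scatter). For the compounds shown here, the weak result is therefore not confined to 2-hydroxynaphthalen-1-yl, since 3-methylfuran-2-yl, with 6 heavy atoms and 0 hydrogen-bond donors against 11 heavy atoms and 1 donor, also gives no number; compound 1 and compound 2 remain the only compounds with a measurable value. Compound 3 and compound 4 both stand at a limit of the assay, so the step between them cannot be read: the limit of > 100 ug/mL in this assay, at which 2 of the 4 values shown sit.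

As far as these compounds go, it remains open whether the 3-methyl group or the furan ring itself accounts for the result of compound 4. From the compounds shown here alone, it is also open how a plain phenyl group, or a phenyl group bearing an amine or a carboxylic acid, would behave at this carbon.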